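Side-chain swap at the alpha carbon of compound 2

The source may report more compounds than this note shows. Statements on the series, on what has been measured and on what is new or still open speak of the compounds shown alone.

Three compounds of this series have numbers in a functional assay on the whole organism (Tail, strain ICR) with Mus musculus as the target, in the tail flick test, with a stated time of 90 min, at a dose of 25 umol/kg by the oral route; on this read-out higher numbers stand for a stronger effect at the one dose given and lower numbers for a weaker effect. Compound 1 `NCCCC[C@H](NC(=O)CN(c1nc(Cl)nc2[nH]cnc12)C1CC1)C(=O)OCc1ccccc1` gives 35.3%, compound 3 `O=C(CN(c1nc(Cl)nc2[nH]cnc12)C1CC1)N[C@@H](CCC(=O)OCc1ccccc1)C(=O)OCc1ccccc1` gives 50%, and compound 2 `CC[C@H](C)[C@H](NC(=O)CN(c1ncnc2c1ncn2C1CCCCO1)C1CC1)C(=O)OCc1ccccc1` gives 22.6%, the lowest of the three, with both gaps beyond the scatter: compound 1 sits higher by a modest margin and compound 3 further still. Going by the values given here, the only single-point step among measured compounds is a number 14.7 percentage points higher from compound 1 to compound 3 (beyond the scatter).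

Compound 4 `NC(=O)C[C@H](NC(=O)CN(c1ncnc2c1ncn2C1CCCCO1)C1CC1)C(=O)OCc1ccccc1` differs from compound 2 as follows: carbamoylmethyl in place of sec-butyl on a saturated chain carbon bound to an amide-type nitrogen and a carbonyl carbon. This change sits on a saturated chain carbon bound to an amide-type nitrogen and a carbonyl carbon, a different place from the step from compound 1 to compound 3, and neither compound 1 nor compound 3 carries sec-butyl or carbamoylmethyl; that step therefore does not bear directly on the present one. Among the compounds with values here, no measured pair tests this exchange. The expected step is a number 2.4 percentage points higher from compound 2 to compound 4 (within the scatter), within the scatter. Compound 4 is estimated at 25% in this assay, with a range from 8% to 45%.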

Compound 4, a percentage reported as activity, at one dose (the size of the read-out at that dose, not a potency): 35%
For compound 4 the middle estimate is 10 percentage points below the measured one, within the range that was stated.
By their numbers in this assay, from the lowest: compound 2; then compounds 4 and 1 (each within the scatter of the next); then compound 3.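

In this assay, going by these compounds alone, carbamoylmethyl in place of sec-butyl on a saturated chain carbon bound to an amide-type nitrogen and a carbonyl carbon gives a number 12.4 percentage points higher from compound 2 to compound 4 (beyond the scatter) and is the first measured sign that the read-out responds to the group at this position. Both groups have 4 heavy atoms, whereas the entering group has 1 hydrogen-bond donor and 1 hydrogen-bond acceptor and the leaving group has neither, so the step comes with a change in atom types at an unchanged heavy-atom count. Nothing available gives a cause for this step.

The compounds shown leave open whether a carboxylic acid or an amine at this position would move the number in the same direction, and whether a longer chain ending in the same amide would hold the gain. They also leave open whether the step carries over to the core of compound 1.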